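The compounds below may be only part of what the source reports. "The series", "measured", "known", "first", "only" and "open" are said of these compounds alone.

Measured compounds:
- compound 1, `COc1ccccc1/C=C/c1ccccc1O`, 15 ug/mL
- compound 2, `COc1ccc(/C=C/c2ccccc2O)cc1`, 21 ug/mL
- compound 3, `COc1ccccc1/C=C/c1ccccc1N`, 2.1 ug/mL

All three were tested in an ADME assay on HEK293 cells (Homo sapiens) for inhibition, read by MTT assay, with a stated time of 2 days; a lower number here means a stronger inhibitor, a higher number a weaker inhibitor. Compound 1 and compound 2 are built from the same atoms joined differently; how their two cores differ is not broken down here. In this assay compound 1 gives 15 ug/mL and compound 2 gives 21 ug/mL, two numbers that lie within the usual scatter of each other, so no order between them can be read.

Compound 3 differs from compound 1 in one place: amino in place of hydroxy on an aromatic carbon. That single exchange brought a 7.1-fold lower number from compound 1 to compound 3 (0.85 log units; beyond the scatter), a change beyond the scatter of repeated measurements.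

Compound 4, `COc1ccc(/C=C/c2ccccc2N)cc1`, has not yet been measured in this assay. It stands to compound 2 exactly as compound 3 stands to compound 1: amino in place of hydroxy on an aromatic carbon. The two changes sit in the same kind of place on the same kind of ring, so they are the same change, applied to a different core.

Among the compounds with values here, the expectation for compound 4 rests on compound 2, whose value is 21 ug/mL, and on the step seen before, a 7.1-fold lower number from compound 1 to compound 3 (0.85 log units; beyond the scatter), which is the only example of this change available. A step of similar size is expected here, a 7.0-fold lower number from compound 2 to compound 4 (0.85 log units; beyond the scatter), giving compound 4 an estimated value of 3 ug/mL, with the likely range running from 1.5 ug/mL to 7 ug/mL. Whether a single earlier example carries over to a different core is the open question the measurement will answer.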

Compound 4, half-maximal inhibitory concentration: 0.6 ug/mL
For compound 4 the middle estimate is 5.0-fold (0.70 log units) above the measured one; measured number outside the range, below it.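

In this assay, putting amino in place of hydroxy on the core of compound 2 gave a 35-fold lower number from compound 2 to compound 4 (1.54 log units; beyond the scatter), so the number fell on this core as it did on the core of compound 1. Within the data shown here, the direction of the change therefore carried over, but its size did not, and the two steps differ by more than repeated measurements would explain: the same change on two cores in this assay, a 7.1-fold lower number (0.85 log units; beyond the scatter) from compound 1 to compound 3 and a 35-fold lower number (1.54 log units; beyond the scatter) from compound 2 to compound 4, 4.9-fold (0.69 log units) apart, beyond the scatter of two such steps With only two cores, this shows that a step measured on one core cannot be copied as a fixed amount onto the other, but it does not explain why the size differs, nor does it predict the size or direction of the step on a third core.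

The compounds shown carry only hydroxy or amino at this place, so it remains open what a dimethylamino group, an acetamide or a carboxylic acid would do there. Going by these compounds, it also remains open whether the same change would behave in the same way if a longer chain, such as ethoxy, stood in place of the methoxy group.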